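A few compounds are considered here, and "the series" means these few. Any claim that something is new, unique, unknown or untested is made for them only; others in the source may bear on it.

Measured so far:
- Compound 1, `N#C/C(=C\N1CCN(C(=O)c2ccco2)C1=S)C(=O)Nc1ccc(Cl)cc1`: 11200 nM
- Compound 2, `N#C/C(=C\N1CCN(C(=O)c2ccco2)C1=S)C(N)=O`: 16500 nM

In a functional assay on SK-MEL-5 cells (Homo sapiens) for inhibition, read by sulforhodamine B assay, with a stated time of 48 h (on this read-out lower numbers stand for stronger inhibition of growth and higher numbers for weaker inhibition of growth), compound 2 gives the higher of the two numbers, although a 1.5-fold higher number from compound 1 to compound 2 (0.17 log units; within the scatter) is within the scatter, so the two compounds cannot be ordered. Compound 3, `N#C/C(=C\N1CCN(C(=O)c2ccco2)C1=S)C(=O)c1ccccc1`, carries phenyl in place of amino on a carbonyl carbon, carbamoyl to benzoyl. Within the data shown here, the only measured step, a 1.5-fold higher number from compound 1 to compound 2 (0.17 log units; within the scatter), changed a substituent on the amide nitrogen and moved the number little, so a change at the neighbouring carbonyl is expected to stay within the scatter as well. Compound 3 is therefore estimated at 11000 nM (range 3500 nM to 35000 nM), a step of a 1.5-fold lower number from compound 2 to compound 3 (0.18 log units; within the scatter).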

Compound 3, concentration for 50% growth inhibition: 8300 nM
Compound 3: the middle estimate sits 1.3-fold (0.12 log units) above what was measured, within the range that was stated.
By their numbers in this assay, from the lowest: compounds 3, 1 and 2 (each within the scatter of the next).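

In this assay phenyl on the carbonyl carbon gives a 2.0-fold lower number from compound 2 to compound 3 (0.30 log units; within the scatter) when it replaces amino and a 1.3-fold lower number from compound 1 to compound 3 (0.13 log units; within the scatter) when it replaces (4-chlorophenyl)amino. Both steps lie within the scatter, so at this position the number shows no readable shift, even with the amide nitrogen gone and a phenyl ring bound directly to the carbonyl carbon. Nothing available explains this result. Still open, as far as these compounds go, is whether a carboxylic acid or a longer alkyl chain on this carbonyl carbon would move the number beyond the scatter.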